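Benzylthioamide series: nitro to bromo on the benzyl ring

The compounds below may be only part of what the source reports. "The series", "measured", "known", "first", "only" and "open" are said of these compounds alone.

compound 1 `COc1cc(N(Cc2ccc(F)cc2)C(=O)CSc2nc3ccccc3s2)cc(OC)c1OC` 59800 nM
compound 2 `COc1cc(CN(C(=O)CSc2nc3ccccc3s2)c2cc(OC)c(OC)c(OC)c2)cc(OC)c1OC` 65300 nM
compound 3 `COc1ccc(CN(C(=O)CSc2nc3ccccc3s2)c2cc(OC)c(OC)c(OC)c2)cc1[N+](=O)[O-]` 1280 nM

In a functional assay on HCT-116 cells (Homo sapiens) for antiproliferative activity, read by MTT assay, with a stated time of 48 h (on this read-out higher numbers stand for weaker inhibition and lower numbers for stronger inhibition), compound 3 gives the lowest number of the three, beyond the scatter from both neighbours: a 47-fold lower number from compound 1 to compound 3 (1.67 log units; beyond the scatter) and a 51-fold lower number from compound 2 to compound 3 (1.71 log units; beyond the scatter), while a 1.1-fold higher number from compound 1 to compound 2 (0.04 log units; within the scatter). Compound 4 `COc1ccc(CN(C(=O)CSc2nc3ccccc3s2)c2cc(OC)c(OC)c(OC)c2)cc1Br` keeps the core of compound 3 and changes only the benzyl ring: bromo in place of nitro on an aromatic carbon. Within the data shown here, no measured step swaps one group for another on this ring; the two large steps show only that the benzyl aryl group can move the number far. Since the nitro group is lost and nothing here tells what bromo does, a weaker result than compound 3 is expected with wide uncertainty, a 4.7-fold higher number from compound 3 to compound 4 (0.67 log units; beyond the scatter). Compound 4 is estimated at 6000 nM, between 1200 nM and 30000 nM.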

Compound 4, half-maximal inhibitory concentration: 4550 nM
Beside the measured number, compound 4's estimate is 1.3-fold (0.12 log units) above it, and the stated range covers the measured number.
By their numbers in this assay, from the lowest: compound 3; then compound 4; then compounds 1 and 2 (each within the scatter of the next).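

In this assay bromo in place of nitro gives a 3.6-fold higher number from compound 3 to compound 4 (0.55 log units; beyond the scatter) on this aromatic carbon ortho to a methoxy group, so the nitro group is not essential to a low number in this set. The 3-bromo-4-methoxyphenyl group also stands well clear of the other aryl groups, with a 14-fold lower number from compound 2 to compound 4 (1.16 log units; beyond the scatter) and a 13-fold lower number from compound 1 to compound 4 (1.12 log units; beyond the scatter) on the same nitrogen-bound saturated carbon. Nothing available explains the gap between nitro and bromo.

Open, from the compounds shown here alone, is what an amine or a carboxylic acid would give on this carbon. Also open, going by these compounds, is whether the methoxy group is needed alongside bromo.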